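Hydroxyphenyl-substituted pyridines: positional isomer check against topoisomerase inhibition

The source may report more compounds than this note shows. Statements on the series, on what has been measured and on what is new or still open speak of the compounds shown alone.

Two members of this series have been measured so far. Compound 1 `Oc1ccc(-c2cc(-c3ccc(O)cc3)nc(-c3ccc(O)cc3)c2)cc1` was tested in an assay on isolated protein for inhibition of DNA topoisomerase 1 (Homo sapiens), with a stated time of 30 min, tested at 100 uM (on this read-out higher numbers stand for more inhibition at the one concentration tested (going by the name of the read-out) and lower numbers for less inhibition), where compound 1 gives 3.8%. Among the measured compounds shown here, compound 2 `Oc1cccc(-c2cc(-c3ccccc3O)nc(-c3ccccc3O)c2)c1` is the only other measured member; in this assay compound 2 gives 4.9%. Compound 1 has the lower of the two numbers, but the gap to compound 2 lies within the scatter, so the two read as indistinguishable and both show little inhibition at the concentration tested.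

Compound 3 `Oc1ccc(-c2cc(-c3cccc(O)c3)cc(-c3ccc(O)cc3)n2)cc1` is not yet measured. It differs from compound 1 in one place: 3-hydroxyphenyl in place of 4-hydroxyphenyl on an aromatic carbon. For the measured compounds named here, no step between measured compounds is available for this kind of change, so nothing in the data argues for a shift beyond the scatter. Given that compound 1 gives 3.8% and compound 2 gives 4.9%, the expectation for compound 3 in this assay is 5%, with a range from 0% to 15%. The step this estimate implies, a number 1.2 percentage points higher from compound 1 to compound 3 (within the scatter), is expected to stay within the scatter.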

Compound 3, a percentage reported as inhibition, at one concentration (the size of the read-out at that concentration, not a potency): 0%
Compound 3: the middle estimate sits 5 percentage points above what was measured; the measured number falls inside the stated range.
By their numbers in this assay, from the lowest: compounds 3, 1 and 2 (each within the scatter of the next).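

Among the compounds shown here, replacing 4-hydroxyphenyl with 3-hydroxyphenyl on the aromatic carbon opposite the ring nitrogen gives the first one-place comparison, which reads as a number 3.8 percentage points lower from compound 1 to compound 3 (within the scatter) in this assay and so separates the two compounds by no more than the scatter. At this position, the change of hydroxyl placement on the phenyl group does not bring out inhibition at the one concentration tested, and compound 1 and compound 3 read as indistinguishable. No measured data on the cause of this outcome are available.

With all the numbers so small, the compounds shown cannot tell whether this position has any influence on the read-out. As far as these compounds go, whether an amine, a carboxylic acid or a longer chain in place of the hydroxyl at this position would give measurable inhibition remains open.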